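Fluoro step in a cytotoxicity series, working notes

This account rests on a few compounds, and the source may have more. Where it says the series, first, only, none or still open, it means among the compounds named here.

Measured in an ADME assay on Vero cells (Chlorocebus sabaeus) for cytotoxicity, read by MTT assay, with a stated time of 72 h; on this read-out lower numbers stand for higher toxicity in this test and higher numbers for lower toxicity in this test:
- compound 1 `Cc1c(C(=O)CSc2ccccc2)[n+]([O-])c2ccccc2[n+]1[O-]` gives 50 ug/mL
- compound 2 `Cc1c(C(=O)CSc2ccc(F)cc2)[n+]([O-])c2ccccc2[n+]1[O-]` gives 50 ug/mL
- compound 3 `Cc1c(C(=O)CSCCNC(=O)c2ccccc2)[n+]([O-])c2ccccc2[n+]1[O-]` is reported only as a limit of the assay, > 100 ug/mL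

Compound 2 arises from compound 1 by fluoro in place of hydrogen on an aromatic carbon. In this assay this gave no change at the digits printed from compound 1 to compound 2 (within the scatter). Compound 4 `Cc1c(C(=O)CSCCNC(=O)c2ccc(F)cc2)[n+]([O-])c2ccccc2[n+]1[O-]` arises from compound 3 by fluoro in place of hydrogen on an aromatic carbon, the same change at the same kind of place, here on the benzoyl rather than the phenylsulfanyl part. The difference between the core of compound 1 and the core of compound 3 is not broken down here.

Compound 3 sits at the limit of > 100 ug/mL in this assay, at which 1 of the 3 values shown sits. Compound 4 is therefore expected to remain near that limit, with an estimated step that the limit leaves unreadable from compound 3 to compound 4, an expectation resting on no change at the digits printed from compound 1 to compound 2 (within the scatter). For compound 4 the estimate in this assay is 150 ug/mL, expected to fall between 90 ug/mL and 300 ug/mL.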

Compound 4, half-maximal cytotoxic concentration: > 100 ug/mL
Compound 4 was reported as a limit (the forecaster's own chance of this, stated with the estimate: 75%); the middle value does not contradict the limit.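

No new step can be read from compound 3 to compound 4, since each is reported only as a limit of the assay: the limit of > 100 ug/mL in this assay, at which 2 of the 4 values shown sit. Going by these compounds, whether fluoro in place of hydrogen on the benzoyl part changes the half-maximal cytotoxic concentration remains open.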